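The compounds below may be only part of what the source reports. "The series", "measured", "known", "first", "only" and "open" are said of these compounds alone.

Measured in an ADME assay on S9 fraction from liver (Rattus norvegicus) for metabolic stability, read by LC-MS, using NADPH, with a stated time of 30 min; on this read-out higher numbers stand for a more stable compound and lower numbers for a less stable compound:
- Compound 1 `CCCCCCCCc1ccc(OCC(=O)Cn2ncnn2)cc1`: < 5% (a limit of the assay, not a number)
- Compound 2 `CCCCCCCCc1ccc(OCC(=O)Cn2cnnn2)cc1`: 22%

Among the measured compounds shown here, compound 2 therefore holds the only true number so far, and it is the higher-placed of the pair. The next compound to be tested is compound 3 `CCCCCCCCc1ccc(OCC(=O)Cn2nnc(C)n2)cc1`, where 5-methyl-2H-tetrazol-2-yl takes the place of 1H-tetrazol-1-yl on a saturated chain carbon bound to a carbonyl carbon: 5-methyl-2H-tetrazol-2-yl in place of 1H-tetrazol-1-yl on a saturated chain carbon bound to a carbonyl carbon. This restores the 2H-tetrazol-2-yl attachment of compound 1, now with a methyl added. For the measured compounds named here, one measured step bears on the change: a number at least 17 percentage points higher from compound 1 to compound 2 (beyond the scatter). Going by these compounds, its full size is unknown, since it starts from a limit. Going by the values given here, no measured step covers the methyl, so a partial return is the more cautious expectation. The expected change is a number 12 percentage points lower from compound 2 to compound 3 (beyond the scatter), a modest fall. Compound 3 is estimated at 10%, with an expected range from 3% to 25%.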

Compound 3, percent of the compound remaining: < 5%
Compound 3 ended at the assay's limit; the forecaster's own chance of this, stated with the estimate: 35%; middle value at least 5 percentage points away from the limit.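

In this assay, 5-methyl-2H-tetrazol-2-yl in place of 1H-tetrazol-1-yl on a saturated chain carbon bound to a carbonyl carbon gives a number at least 17 percentage points lower from compound 2 to compound 3 (beyond the scatter). Adding a methyl to the 2H-tetrazol-2-yl ring therefore does not recover the standing of compound 2, whose 1H-tetrazol-1-yl remains the only group of the three at this place with a true number. The step from compound 1 to compound 3 cannot be read, so any effect of the methyl itself stays hidden, because both compounds sit at the assay's limit: the limit of < 5% in this assay, at which 2 of the 3 values shown sit.

Going by these compounds, it remains open whether a methyl on the 1H-tetrazol-1-yl ring would keep compound 2 at its level. Also open, on these data alone, is how a different group at this place, such as a carboxylic acid or a simple amide, would compare with compound 2 in this assay.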